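From 4-methylphenyl to 2-methylphenyl

A few compounds are considered here, and "the series" means these few. Any claim that something is new, unique, unknown or untested is made for them only; others in the source may bear on it.

Going by the values given here, compound 2 (`CCCCCCCCCCCCCCNC(=O)[C@H](CO)/N=C/c1ccc(C)cc1`) gives 102000 nM in a functional assay on cells (Homo sapiens) for cytotoxicity, read by MTT assay, with a stated time of 24 h (on this read-out higher numbers stand for weaker inhibition and lower numbers for stronger inhibition), and sits within the scatter of compound 1 (`CCCCCCCCCCCCCCNC(=O)[C@H](CO)/N=C/c1cccc(C)c1`) at 82900 nM as its only neighbour on these numbers. Compound 3 (`CCCCCCCCCCCCCCNC(=O)[C@H](CO)/N=C/c1ccccc1C`) is still unmeasured and differs from compound 2 by 2-methylphenyl in place of 4-methylphenyl on a carbon with a double bond to nitrogen in one place, with 2-methylphenyl in place of 4-methylphenyl on a carbon with a double bond to nitrogen. Among the compounds with values here, the one measured step that bears on this is a 1.2-fold higher number from compound 1 to compound 2 (0.09 log units; within the scatter) and it exchanges 3-methylphenyl for 4-methylphenyl within the scatter, so no step beyond the scatter is expected. The step expected in this assay is a 1.1-fold lower number from compound 2 to compound 3 (0.05 log units; within the scatter) and stays small. Compound 3 is estimated at 90000 nM and is expected to fall between 50000 nM and 160000 nM.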

Compound 3, half-maximal inhibitory concentration: 87700 nM
Beside the measured number, compound 3's estimate is 1.0-fold (0.01 log units) above it; low and high end bracket the measured number.
By their numbers in this assay, from the lowest: compounds 1, 3 and 2 (each within the scatter of the next).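

In this assay, 2-methylphenyl in place of 4-methylphenyl gives a 1.2-fold lower number from compound 2 to compound 3 (0.07 log units; within the scatter), and 2-methylphenyl in place of 3-methylphenyl gives a 1.1-fold higher number from compound 1 to compound 3 (0.02 log units; within the scatter). Going by these compounds alone, all three methylphenyl groups on the carbon with a double bond to nitrogen have now been compared, and no pair among them lies beyond the scatter. Nothing available explains this closeness. The compounds shown do not tell whether a group other than methylphenyl at this place, such as an aminophenyl or a carboxyphenyl, would give a different number. They also leave open what a shorter chain would do.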